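The compounds below may be only part of what the source reports. "The series", "measured", "known", "first", "only" and "open" are said of these compounds alone.

Compound 1 `Cc1cc(Nc2cc(-c3ccccc3)[nH]n2)n2nc(SCc3csc4ccccc34)nc2n1` — 3470 nM
Compound 2 `Cc1cc(Nc2cc(-c3ccc(Cl)cc3)[nH]n2)n2nc(SCc3ccc(Br)cc3)nc2n1` — 3620 nM

In a functional assay on MCF7 cells (Homo sapiens) for inhibition, read by MTT assay, with a stated time of 72 h (on this read-out lower numbers stand for stronger inhibition and higher numbers for weaker inhibition), compound 1 gives 3470 nM, the smaller of the two numbers, while compound 2 gives 3620 nM; the gap between them is within the scatter, so the two are not separated by these data. Among the measured compounds shown here, no pair of measured compounds differs in a single place, so no measured step is available to guide a prediction. Compound 3 `COc1ccc(CSc2nc3nc(C)cc(Nc4cc(-c5ccccc5)[nH]n4)n3n2)cc1` differs from compound 1 in one place: 4-methoxyphenyl in place of 1-benzothiophen-3-yl on a saturated chain carbon bound to a sulfur. Because compound 1 gives 3470 nM and compound 2, with a different group on the same chain carbon, gives 3620 nM, the expected step of a 1.2-fold higher number from compound 1 to compound 3 (0.08 log units; within the scatter) is small and is estimated to lie within the scatter, with no direction favoured. Compound 3 is therefore expected to give 4200 nM. For compound 3 the estimated range runs from 1400 nM to 13000 nM.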

Compound 3, half-maximal inhibitory concentration: 4020 nM
The estimate for compound 3 lay 1.0-fold (0.02 log units) above the measured number; measured number inside the range.
By their numbers in this assay, from the lowest: compounds 1, 2 and 3 (each within the scatter of the next).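

In this assay, among the compounds shown here, replacing 1-benzothiophen-3-yl with 4-methoxyphenyl on a saturated chain carbon bound to a sulfur gives a 1.2-fold higher number from compound 1 to compound 3 (0.06 log units; within the scatter) and provides the first single-place step at this position. The two compounds are not separated by this read-out, even though the group entering has one six-membered aromatic ring of carbon only and the group leaving also has a five-membered aromatic ring with one hetero atom. The data give no measured basis for explaining this result.

The compounds shown leave open whether the value would remain in the same range with a non-aromatic group at this position, such as an amine or a carboxylic acid. They also do not show what a longer chain between the sulfur and the aromatic ring would do.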